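Same Atoms, Joined Differently: From Compound 2 to Compound 4

A few compounds are considered here, and "the series" means these few. Any claim that something is new, unique, unknown or untested is made for them only; others in the source may bear on it.

Of the compounds shown here, three have been tested in an assay on isolated protein for binding affinity to corticotropin-releasing factor receptor 1 (Homo sapiens); on this read-out higher numbers stand for weaker inhibition and lower numbers for stronger inhibition. Compound 1, with the structure `CCN(c1nc(C)cc(C)n1)c1ccc(OC)cc1Br`, gives 35 nM. Compound 2, with the structure `CCCN(CCC#N)c1nc(C)nc(N(CC)c2ccc(N(C)C)cc2C)n1`, gives 7 nM, the lower of the two numbers, and the gap to compound 1 is larger than the usual scatter of this assay. Going by the values given here, compound 3, with the structure `CCCCN(Cc1nn[nH]n1)c1cc(C)nc(N(CC)c2ccc(C(C)C)cc2Br)n1`, returns only a limit of the assay, > 1000 nM, so no number is known for it; this is the one limit among the values shown (the limit of > 1000 nM in this assay, at which 1 of the 3 values shown sits).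

Compound 4, with the structure `CCCCN(CC#N)c1nc(C)nc(N(CC)c2ccc(N(C)C)cc2C)n1`, has not yet been measured. It differs from compound 2 in a single place: butyl(cyanomethyl)amino in place of (2-cyanoethyl)(propyl)amino on an aromatic carbon. The two compounds contain the same atoms, joined differently. Among the compounds with values here, no measured pair in this set shows what such a rearrangement does, so the expectation rests on compound 2 alone. The expected step is a 1.4-fold higher number from compound 2 to compound 4 (0.15 log units; within the scatter), within the usual scatter, with no direction favoured. Compound 4 is therefore expected to give about 10 nM in this assay, with a range from 3 nM to 35 nM.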

Compound 4, inhibition constant: 8 nM
For compound 4 the middle estimate is 1.3-fold (0.10 log units) above the measured one, within the range that was stated.
By their numbers in this assay, from the lowest: compounds 2 and 4 (each within the scatter of the next); then compound 1. At a limit, above all of these: compound 3.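

In this assay, putting butyl(cyanomethyl)amino in place of (2-cyanoethyl)(propyl)amino gives a 1.1-fold higher number from compound 2 to compound 4 (0.06 log units; within the scatter), so the two compounds cannot be told apart on this read-out. Going by these compounds alone, this is the first direct comparison in the set at this place, the aromatic carbon between two ring nitrogen atoms. It shows that here the same atoms can be shared out differently between the two chains on the amino nitrogen with no change that this assay can detect.

From the compounds shown here alone, whether the reading would hold with a primary amine or a carboxylic acid in place of the nitrile, or with a longer chain than butyl, stays open. The data shown also give no measured basis for explaining why compound 2 and compound 4 read alike.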